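A Piperidine Arm in Place of a Sulfur Substituent

The source may hold more compounds than are shown below. What is called first, only, known or untested is meant among the compounds shown, and "the series" means these compounds.

Compound 1 `CCOC(=O)C1=C(C)N/C(=C/c2cc(C)n(-c3ccc(Cl)cc3)c2C)C1=O` carries a chloro group on a six-membered aromatic ring of carbon only; in a physicochemical assay for lipophilicity, read by HPLC, at pH 7.4 (a lower number here means a more polar compound, a higher number a more lipophilic compound), compound 1 gives 3.4. Compound 2 `CCOC(=O)C1=C(C)N/C(=C/c2cc(C)n(-c3ccc(SC(F)(F)F)cc3)c2C)C1=O` bears a (trifluoromethyl)sulfanyl group at the same place, but in this assay compound 2 stands at "not determined" (no result reported), so no number exists for it and it cannot be placed beside compound 1. Compound 3 `CCOC(=O)C1=C(C)N/C(=C/c2cc(C)n(-c3ccc(CN4CCCCC4)cc3)c2C)C1=O` is the compound still to be measured: the change from compound 2 to compound 3 is (piperidin-1-yl)methyl in place of (trifluoromethyl)sulfanyl on an aromatic carbon, a (piperidin-1-yl)methyl in place of (trifluoromethyl)sulfanyl on an aromatic carbon. Within the data shown here, no step between measured compounds is recorded, and compound 2 itself has no number, so the size of the step to compound 3 rests on expectation alone; the expected direction in this assay is downward, by an amount that should exceed the scatter, toward the more polar side. With compound 1 and its 3.4 as the only anchor, compound 3 is expected to give about 2.4 in this assay, within a range from 1.6 to 3.2.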

Compound 3, distribution coefficient: 8.5
Compound 3: the middle estimate sits 6.10 log units below what was measured; the measured number lies above the stated range.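

In this assay, among these compounds, (piperidin-1-yl)methyl in place of chloro on an aromatic carbon gives a number 5.10 log units higher from compound 1 to compound 3 (beyond the scatter), the first measured change at this position and one that shows the read-out here can move upward by a large amount when a six-membered non-aromatic ring with a hetero atom enters. The step from compound 2 to compound 3 cannot be read, as compound 2 has no number, so this single comparison with compound 1 is all that can be said about the position, and it rests on one pair. The data shown offer no measurement that accounts for the size or direction of this step.

The compounds shown leave open whether the step goes with the piperidine ring, its nitrogen or the methyl link that joins it to the aromatic ring. As far as these compounds go, a (morpholin-4-yl)methyl group, an open-chain amine such as (dimethylamino)methyl, or a cyclohexylmethyl group at the same place could separate these parts, and where the (trifluoromethyl)sulfanyl group of compound 2 falls on this scale also remains unknown.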